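Adding a phenyl to compound 3

A few compounds are considered here, and "the series" means these few. Any claim that something is new, unique, unknown or untested is made for them only; others in the source may bear on it.

Measured in a functional assay for inhibition, with Rattus norvegicus as the target; on this read-out lower numbers stand for stronger inhibition and higher numbers for weaker inhibition:
- Compound 1 `Nc1c(Nc2cccnc2)c(=O)c1=O`: > 30000 nM
- Compound 2 `CC(C)(C)/N=c1\c(O)c(O)\c1=N/c1cccc2cnccc12`: 1840 nM
- Compound 3 `CC(/N=c1\c(O)c(O)\c1=N/c1ccccc1)C(C)(C)C`: 5400 nM

The entry for compound 1, > 30000 nM, is a limit of the assay and not a number.

That leaves two true numbers in this assay. Compound 3 has the higher of them at 5400 nM, while compound 2 gives 1840 nM, a gap beyond the usual scatter. For the measured compounds named here, these compounds differ in more than one place, so no measured step isolates a single change.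

The next compound is compound 4 `CC(/N=c1\c(O)c(O)\c1=N/c1ccc(-c2ccccc2)cc1)C(C)(C)C`, which differs from compound 3 in one place: phenyl in place of hydrogen on an aromatic carbon. A phenyl replaces a hydrogen on an aromatic carbon, para to a large group.

Going by the values given here, with no measured step as a guide, the expectation starts from compound 3 at 5400 nM and is deliberately broad. The expected change is a 1.4-fold lower number from compound 3 to compound 4 (0.13 log units; within the scatter), with no shift beyond the scatter anticipated. For compound 4 the estimated value is 4000 nM, with an expected range from 800 nM to 20000 nM.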

Compound 4, half-maximal inhibitory concentration: > 30000 nM
Compound 4: a limit, no number; the forecaster's own chance of this, stated with the estimate: 15%; at least 7.5-fold (0.87 log units) between middle value and limit.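

In this assay compound 4 gives > 30000 nM, which is a limit of the assay and not a number. This is the only step shown that isolates a single change, and it runs toward weaker inhibition: phenyl in place of hydrogen on an aromatic carbon, para to a large group, gives an at least 5.5-fold higher number from compound 3 to compound 4 (0.74 log units; beyond the scatter). The full size of this loss cannot be read, because the step is bounded only by the limit of the assay: the limit of > 30000 nM in this assay, at which 2 of the 4 values shown sit.

The compounds shown leave open whether the weaker inhibition belongs to phenyl itself or would follow from any group at this position. Going by these compounds, a methyl, a methoxy or an amine on the same aromatic carbon would bear on that question, and how far compound 4 lies past the limit remains unknown.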